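Estimating Compound 4 from Its Halogen Neighbours

This account rests on a few compounds, and the source may have more. Where it says the series, first, only, none or still open, it means among the compounds named here.

Measured in an ADME assay on A549 cells (Homo sapiens) for cytotoxicity, read by resazurin assay, with a stated time of 48 h; a lower number here means that less compound is tolerated, a higher number that more compound is tolerated:
compound 1 `O=C(Nc1ccc(NCc2cccc(C(F)(F)F)c2)cc1Cl)c1cc(Cl)ccc1O` gives 13300 nM
compound 2 `O=C(Nc1ccc(NCc2cc(F)cc(Cl)c2)cc1Cl)c1cc(Cl)ccc1O` gives 11100 nM
compound 3 `O=C(Nc1ccc(NCc2cc(Cl)cc(C(F)(F)F)c2)cc1Cl)c1cc(Cl)ccc1O` gives 30900 nM

Compound 3 has the highest number of the three, and its gaps to both others lie beyond the scatter. Compound 4 `O=C(Nc1ccc(NCc2cc(F)cc(C(F)(F)F)c2)cc1Cl)c1cc(Cl)ccc1O` keeps everything in compound 3 except one substituent: fluoro in place of chloro on an aromatic carbon.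

Among the compounds with values here, no measured step makes this exact swap, so the evidence is indirect. Adding chloro in place of hydrogen gave a 2.3-fold higher number from compound 1 to compound 3 (0.37 log units; beyond the scatter), and trifluoromethyl in place of fluoro gave a 2.8-fold higher number from compound 2 to compound 3 (0.44 log units; beyond the scatter). Both steps lead into compound 3 and both are modest. Compound 4 is therefore expected to fall somewhat back from compound 3, probably landing between compound 1 and compound 3.

The expected change in this assay is a 1.7-fold lower number from compound 3 to compound 4 (0.23 log units; within the scatter), a small move towards a lower number.

For compound 4 the estimated value is 18000 nM, with an expected range from 9000 nM to 36000 nM.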

Compound 4, half-maximal cytotoxic concentration: 30900 nM
Compound 4: middle estimate off by 1.7-fold (0.23 log units), on the low side, within the range that was stated.
By their numbers in this assay, from the lowest: compounds 2 and 1 (each within the scatter of the next); then compounds 3 and 4 (each within the scatter of the next).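

In this assay, fluoro in place of chloro on this aromatic carbon, meta to a trifluoromethyl group, gives no change at the digits printed from compound 3 to compound 4 (within the scatter), so this assay does not separate the two halogens here. Fluoro in place of hydrogen gives a 2.3-fold higher number from compound 1 to compound 4 (0.37 log units; beyond the scatter), and trifluoromethyl in place of chloro at the other substituted carbon gives a 2.8-fold higher number from compound 2 to compound 4 (0.44 log units; beyond the scatter), so with fluoro or chloro at this position, a hydrogen or chloro in place of the trifluoromethyl group is what goes with the lower numbers. Nothing on hand explains why fluoro and chloro match at this position.

Still open, as far as these compounds go, is whether bromo, a methoxy group or an amine at this position would match them as well. Also open, from the compounds shown here alone, is whether fluoro and chloro would still match without the trifluoromethyl group on the same ring.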